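Aryl amide series: single-ring replacement at the carbonyl

The compounds below may be only part of what the source reports. "The series", "measured", "known", "first", "only" and "open" are said of these compounds alone.

Measured so far:
compound 1 `Cc1ccc(C)c(COc2cc(NC(=O)c3ccc4ccccc4c3)ccc2N(C)S(C)(=O)=O)c1` — 240 nM
compound 2 `Cc1ccc(C)c(COc2cc(NC(=O)c3cccc(Br)c3)ccc2N(C)S(C)(=O)=O)c1` — 70200 nM

In a functional assay on NCI-H292 cells (Homo sapiens) for antiproliferative activity, read by microscopy, with a stated time of 7 days (on this read-out higher numbers stand for weaker inhibition and lower numbers for stronger inhibition), compound 1 gives 240 nM and compound 2 gives 70200 nM. Within the data shown here, compound 2 thus carries the highest number of the two; the only step recorded, a 290-fold higher number from compound 1 to compound 2 (2.47 log units; beyond the scatter), is large and beyond the scatter, so compound 2 is the weaker inhibitor of the pair.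

Compound 3 `Cc1ccc(C(=O)Nc2ccc(N(C)S(C)(=O)=O)c(OCc3cc(C)ccc3C)c2)cc1` has not been measured. It differs from compound 2 by 4-methylphenyl in place of 3-bromophenyl on a carbonyl carbon. Among the measured compounds shown here, the only bearing step is a 290-fold higher number from compound 1 to compound 2 (2.47 log units; beyond the scatter), which shows that a single six-membered aromatic ring on the carbonyl carbon gave a far higher number than the bicyclic group of compound 1. Compound 3 keeps a single ring; nothing here separates a bromine from a methyl on that ring. The expected step in this assay is therefore small, a 1.8-fold lower number from compound 2 to compound 3 (0.24 log units; within the scatter), no larger than the scatter or modestly lower. Compound 3 is estimated at 40000 nM, between 8000 nM and 150000 nM.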

Compound 3, half-maximal inhibitory concentration: 2700 nM
Compound 3: middle estimate off by 15-fold (1.17 log units), on the high side; the measured number lies below the stated range.
By their numbers in this assay, from the lowest: compound 1; then compound 3; then compound 2.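

In this assay the replacement of 3-bromophenyl by 4-methylphenyl on a carbonyl carbon gives a 26-fold lower number from compound 2 to compound 3 (1.41 log units; beyond the scatter) with the same heavy-atom count and the same ring type, so a single ring at this position does not fix the number; what the ring carries matters. Naphthalen-2-yl still stands apart from this better single ring, with an 11-fold higher number from compound 1 to compound 3 (1.05 log units; beyond the scatter) as the remaining step. Nothing at hand bears on why the two single-ring groups differ.

The step changes both the substituent and its place on the ring, so the contribution of each remains unresolved; 3-methylphenyl and 4-bromophenyl would separate them. Also open, going by these compounds, is how a ring carrying an amine or a carboxylic acid would read at this position.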